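This account rests on a few compounds, and the source may have more. Where it says the series, first, only, none or still open, it means among the compounds named here.

Two esters of the same chromone-derived acid were examined first. Compound 1 `COC(=O)c1c(Br)cc(Br)cc1OC(=O)COc1cc(O)c2c(=O)cc(-c3ccccc3)oc2c1` carries two bromo groups on the benzoate ring, and compound 2 `COC(=O)c1c(Cl)cc(Cl)cc1OC(=O)COc1cc(O)c2c(=O)cc(-c3ccccc3)oc2c1` carries two chloro groups in the matching positions. In a functional assay on cells (T-cell, Mus musculus, strain BALB/c) for inhibition, read by MTT assay, with a stated time of 72 h (on this read-out higher numbers stand for weaker inhibition and lower numbers for stronger inhibition), compound 1 gives 45700 nM, and in this assay compound 2 gives 43600 nM. The two numbers lie within the usual scatter of each other, so compound 2 cannot be set apart from compound 1 on these data; swapping one pair of halogens for the other leaves the read-out unchanged.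

Compound 3 `COC(=O)c1ccc(Cl)cc1OC(=O)COc1cc(O)c2c(=O)cc(-c3ccccc3)oc2c1` has not yet been measured in this assay. It differs from compound 2 in one place: hydrogen in place of chloro on an aromatic carbon.

Among the measured compounds shown here, nothing among the measured pairs shows what removing a halogen does here; the only comparison available, between compound 1 and compound 2, concerns exchanging halogens, not losing one. The step from compound 2 to compound 3 is therefore expected to be small, most likely a modest move toward weaker inhibition, a 1.3-fold higher number from compound 2 to compound 3 (0.10 log units; within the scatter), and possibly nothing beyond the scatter. Compound 3 is estimated at 55000 nM, with a likely range from 25000 nM to 120000 nM.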

Compound 3, half-maximal inhibitory concentration: 12400 nM
For compound 3 the middle estimate is 4.4-fold (0.65 log units) above the measured one; measured number outside the range, below it.
By their numbers in this assay, from the lowest: compound 3; then compounds 2 and 1 (each within the scatter of the next).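

Taking away the chloro group ortho to the methoxycarbonyl group, with hydrogen in its place, gives in this assay a 3.5-fold lower number from compound 2 to compound 3 (0.55 log units; beyond the scatter), so inhibition becomes stronger by a modest step that lies beyond the scatter. Among the compounds shown here, the earlier pair showed only that exchanging one pair of halogens for the other left the read-out unchanged; it could not show that this aromatic carbon responds to losing its halogen altogether, and the present step shows that it does, with the remaining chloro group, meta to this carbon, kept in place. Nothing available here accounts for why this change lowers the number.

The compounds shown leave open whether the remaining chloro group can also give way to hydrogen, and whether the same change would lower the number in the bromo series of compound 1. They also leave open how a methoxy group or an amine would compare with hydrogen at this carbon, and whether a carboxylic acid in place of the methoxycarbonyl group would keep the lower number of compound 3.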